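The source may hold more compounds than are shown below. What is called first, only, known or untested is meant among the compounds shown, and "the series" means these compounds.

Compound 2 `Cc1n[nH]c2nc(-c3ccc(NS(=O)(=O)c4cc(Cl)ccc4F)cc3)nc(OCC3CN(C(C)C)C3)c12` is a close relative of compound 1 `Cc1n[nH]c2nc(-c3ccc(NS(=O)(=O)c4cc(Cl)ccc4F)cc3)nc(OCC3(CN)COC3)c12`; the two share a core and differ only in the group on a saturated chain carbon bound to an oxygen on an aromatic ring. In an assay for inhibition of serine/threonine-protein kinase Sgk1 (Homo sapiens), with stated times of 30 min and 60 min, in the presence of a further agent that is not named here (on this read-out lower numbers stand for stronger inhibition and higher numbers for weaker inhibition), compound 1 gives 1 nM, and in this assay compound 2 gives 1 nM, so compound 2 stands level with compound 1 on the numbers shown, the step of no change at the digits printed from compound 1 to compound 2 (within the scatter) lying within the scatter.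

Compound 3 `Cc1n[nH]c2nc(-c3ccc(NS(=O)(=O)c4cc(Cl)ccc4F)cc3)nc(OCC3CNCCO3)c12` carries a further exchange at that same place: morpholin-2-yl in place of 1-isopropylazetidin-3-yl on a saturated chain carbon bound to an oxygen on an aromatic ring. Among the compounds with values here, the only measured step that bears on this position is the one just described, and it was flat although a ring bearing a basic nitrogen replaced a ring bearing an aminomethyl group. On that evidence compound 3 is expected to sit close to compound 2 in this assay, with a step of a 1.5-fold higher number from compound 2 to compound 3 (0.18 log units; within the scatter) that is not expected to exceed the scatter in either direction. The estimate for compound 3 in this assay is therefore 1.5 nM, with a range from 0.5 nM to 6 nM.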

Compound 3, half-maximal inhibitory concentration: 2 nM
Estimate against measurement, compound 3: 1.3-fold (0.12 log units) below; measured number inside the range.
By their numbers in this assay, from the lowest: compounds 1, 2 and 3 (each within the scatter of the next).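

In this assay, morpholin-2-yl in place of 1-isopropylazetidin-3-yl gives a 2.0-fold higher number from compound 2 to compound 3 (0.30 log units; within the scatter), and morpholin-2-yl in place of 3-(aminomethyl)oxetan-3-yl gives a 2.0-fold higher number from compound 1 to compound 3 (0.30 log units; within the scatter). Within the data shown here, the earlier pair showed only that two groups on a saturated chain carbon bound to an oxygen on an aromatic ring could not be told apart; these steps extend that to a six-membered non-aromatic ring with 2 hetero atoms, which also brings 1 hydrogen-bond donor and 2 hydrogen-bond acceptors where 1-isopropylazetidin-3-yl has 0 and 1, and all three compounds remain within the scatter of one another. Nothing available here offers an explanation for why these three groups cannot be told apart in this assay.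

All three groups contain a nitrogen, so the compounds shown leave open whether the same reading would hold for a group without one, such as a carboxylic acid, a plain cyclohexyl ring or a simple methyl group. They also leave open whether a longer chain between the oxygen and the amine would read the same way.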